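The source may report more compounds than this note shows. Statements on the series, on what has been measured and on what is new or still open speak of the compounds shown alone.

Compound 1 `CC1(C)CN(c2cc(COc3ccc(F)c(F)c3F)nc(-c3ccccn3)n2)C1`: 25.1 nM
Compound 2 `CC1(C#N)CN(c2cc(COc3ccc(F)c(F)c3F)nc(-c3ccccn3)n2)C1`: 158 nM

Going by the values given here, in a functional assay on cells for antagonist activity at Free fatty acid receptor 1 (Homo sapiens), read by TR-FRET and inositol phosphate accumulation, with a stated time of 2 h (a lower number here means a stronger inhibitor, a higher number a weaker inhibitor), compound 2 stands highest of the two numbers; the only measured step is a 6.3-fold higher number from compound 1 to compound 2 (0.80 log units; beyond the scatter), which concerns the substituent on the azetidine ring. Compound 3 `Fc1ccc(OCc2cc(OCC(F)(F)F)nc(-c3ccccn3)n2)c(F)c1F` carries 2,2,2-trifluoroethoxy in place of 3-cyano-3-methylazetidin-1-yl on an aromatic carbon. Among the compounds with values here, no measured step bears on removing the whole azetidine and putting an alkoxy group in its place, so the direction of this assay is open and the range must be wide. Compound 3 is expected to give 300 nM, within 50 nM to 2000 nM. The expected step is a 1.9-fold higher number from compound 2 to compound 3 (0.28 log units; within the scatter), essentially no shift beyond the scatter.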

Compound 3, half-maximal inhibitory concentration: 7.94 nM
Compound 3: middle estimate off by 38-fold (1.58 log units), on the high side; measured number below the stated range.
By their numbers in this assay, from the lowest: compound 3; then compound 1; then compound 2.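

In this assay the azetidine ring is not required on this aromatic carbon: 2,2,2-trifluoroethoxy in place of 3-cyano-3-methylazetidin-1-yl gives a 20-fold lower number from compound 2 to compound 3 (1.30 log units; beyond the scatter), and in place of 3,3-dimethylazetidin-1-yl gives a 3.2-fold lower number from compound 1 to compound 3 (0.50 log units; beyond the scatter). This position therefore accepts a group with no ring, and compound 3 has the lowest number of the three. Nothing given here accounts for this gain. The compounds shown leave open whether the gain follows the fluorines or the ether oxygen. An ethoxy group or a 2,2,2-trifluoroethylamino group on this carbon would separate the two.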